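A Methyl Step from Compound 3 to Compound 4

This account rests on a few compounds, and the source may have more. Where it says the series, first, only, none or still open, it means among the compounds named here.

Compound 1 `CC(=O)N1CC=C(c2ccn3c(-c4ccc(NC(=O)c5ccc([N+](=O)[O-])o5)cc4)cnc3c2)CC1`: 410 nM in a functional assay on AGS cells (Homo sapiens) for antiproliferative activity, read by CCK-8 assay, with a stated time of 72 h; a higher number here means a weaker inhibitor, a lower number a stronger inhibitor
Compound 2 `O=C(Nc1ccc(-c2cnc3cc(N4CCCC4)ccn23)cc1)c1ccc([N+](=O)[O-])o1`: 1240 nM
Compound 3 `O=C(Nc1ccc(-c2cnc3ccccn23)cc1)c1ccc([N+](=O)[O-])o1`: 360 nM

Compound 3 has the lowest of the three numbers in this assay; compound 1 lies within the scatter of it (a 1.1-fold lower number from compound 1 to compound 3 (0.06 log units; within the scatter)), while compound 2 lies beyond it (a 3.4-fold lower number from compound 2 to compound 3 (0.54 log units; beyond the scatter)). Compound 4 `Cc1cc(NC(=O)c2ccc([N+](=O)[O-])o2)ccc1-c1cnc2ccccn12` differs from compound 3 by methyl in place of hydrogen on an aromatic carbon. Among the compounds with values here, none of the measured steps touches this place: a 3.0-fold higher number from compound 1 to compound 2 (0.48 log units; beyond the scatter) and the two steps above all concern replacements on an aromatic carbon of the shared core, a different position from the one where the methyl enters. The data give no guide to the methyl itself, so no step beyond the scatter is expected in this assay. Compound 4 is therefore expected to give 400 nM, in the range 180 nM to 900 nM. The expected change is a 1.1-fold higher number from compound 3 to compound 4 (0.05 log units; within the scatter).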

Compound 4, half-maximal inhibitory concentration: 390 nM
Compound 4: the middle estimate sits 1.0-fold (0.01 log units) above what was measured; low and high end bracket the measured number.
By their numbers in this assay, from the lowest: compounds 3, 4 and 1 (each within the scatter of the next); then compound 2.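

In this assay methyl in place of hydrogen on an aromatic carbon, ortho to a group of 9 heavy atoms, is the first change shown at this place, and it stays within the scatter (a 1.1-fold higher number from compound 3 to compound 4 (0.03 log units; within the scatter)). This carbon of the six-membered aromatic ring therefore takes one added carbon with no step beyond the scatter, which compounds 1 and 2 could not show. No measurement here offers an explanation for this result. The compounds shown leave open what an amine, a methoxy group or a longer chain would do on the same carbon, and whether methyl gives the same result on the core of compound 1 or compound 2.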